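Cytotoxicity in a Small Biphenyl Series: Compound 2 to Compound 4

A few compounds are considered here, and "the series" means these few. Any claim that something is new, unique, unknown or untested is made for them only; others in the source may bear on it.

Compound 1 `Nc1cc(-c2ccccc2)ccc1Cn1cncc1CNc1ccc(Cl)c(-c2ccccc2)c1` — in a toxicity assay on NIH3T3 cells (Mus musculus) for cytotoxicity, read by resazurin assay (on this read-out lower numbers stand for an effect already at smaller amounts and higher numbers for an effect only at larger amounts of compound), compound 1 gives > 1000 nM, a limit of the assay.
Compound 2 `COC(=O)c1ccc(NCc2cncn2Cc2ccccc2-c2ccccc2)cc1-c1ccccc1` — in this assay compound 2 gives "not determined" (no result reported).
Compound 3 `Nc1cc(-c2ccccc2)ccc1Cn1cncc1CNc1ccc(-c2nc3ccccc3s2)c(-c2ccccc2)c1` — in this assay compound 3 gives > 1000 nM, a limit of the assay.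

Compound 2 thus stands without a number of its own. The step from compound 1 to compound 3 reads a step that the two limits leave unreadable from compound 1 to compound 3. The change to compound 4 `COC(=O)c1ccc(NCc2cncn2Cc2cccc(N)c2)cc1-c1ccccc1` is 3-aminophenyl in place of 2-phenylphenyl on a saturated chain carbon bound to an aromatic nitrogen. Going by the values given here, no measured step shares this change; the only evidence is the limit of > 1000 nM in this assay, at which 2 of the 3 values shown sit. In this assay compound 4 is therefore expected to sit near that limit, with no readable direction, and its estimated value is 3000 nM with a range from 1000 nM to 20000 nM.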

Compound 4, half-maximal effective concentration: > 10000 nM
Compound 4: only a limit was reported; the forecaster's own chance of this, stated with the estimate: 70%; middle value at least 3.3-fold (0.52 log units) away from the limit.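

Going by these compounds alone, compound 2 carries no number in this assay, so no new step to compound 4 can be read. Compound 4 gives > 10000 nM, a limit and not a number. The compounds shown leave open at what concentration any of them would show an effect in this assay.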